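Capping the Hydroxy Group of Compound 1

A few compounds are considered here, and "the series" means these few. Any claim that something is new, unique, unknown or untested is made for them only; others in the source may bear on it.

Compound 1: `COc1ccc(C2=C(c3ccc(SC)cc3)CC3CCCN3C2=O)cc1O`, 6000 nM
Compound 2: `CSc1ccc(C2=C(c3ccc(F)c(F)c3)C(=O)N3CCCC3C2)cc1`, 200 nM
Compound 3: `CSc1ccc(C2=C(c3ccc(C)c(C)c3)C(=O)N3CCCC3C2)cc1`, 300 nM

In a functional assay on NCI-H520 cells (Homo sapiens) for cytotoxicity (on this read-out lower numbers stand for stronger inhibition of growth and higher numbers for weaker inhibition of growth), compound 1 stands with the highest number of the three measured compounds. Its nearest neighbour is compound 3, and the two steps away from it are both large: a 30-fold lower number from compound 1 to compound 2 (1.48 log units; beyond the scatter) and a 20-fold lower number from compound 1 to compound 3 (1.30 log units; beyond the scatter). Between the two lower values the gap is small: a 1.5-fold higher number from compound 2 to compound 3 (0.18 log units; within the scatter).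

Compound 4, `COc1ccc(C2=C(c3ccc(SC)cc3)CC3CCCN3C2=O)cc1OC`, differs from compound 1 in a single place: methyl in place of hydrogen on an oxygen on an aromatic ring. Among the measured compounds shown here, no measured pair shows this exact change. The two steps that do bear on it, from compound 1 to compound 2 and from compound 1 to compound 3, both swap the whole 3-hydroxy-4-methoxyphenyl for a phenyl carrying no hydroxy, and both give much lower numbers. That suggests the hydroxy of compound 1 goes with its weak result, so a smaller step downward is expected when only the hydroxy is changed to methoxy, with wide uncertainty because the swapped groups in compound 2 and compound 3 differ in more than that.

The expected step is a 4.0-fold lower number from compound 1 to compound 4 (0.60 log units; beyond the scatter). Compound 4 is estimated at 1500 nM, within 400 nM to 6000 nM.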

Compound 4, concentration for 50% growth inhibition: 2000 nM
Compound 4: the middle estimate sits 1.3-fold (0.12 log units) below what was measured; the range from low to high includes it.
By their numbers in this assay, from the lowest: compounds 2 and 3 (each within the scatter of the next); then compound 4; then compound 1.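

Capping the hydroxy as methoxy changes nothing else in compound 1, so this single change can be read on its own in this assay (a 3.0-fold lower number from compound 1 to compound 4 (0.48 log units; beyond the scatter)), a modest step that is beyond the scatter and shows that the hydrogen on this oxygen is not required for growth inhibition. The change accounts for only part of the earlier drops, since compound 4 (2000 nM) still has a higher number than compound 2 (200 nM) and compound 3 (300 nM), and the rest of those drops goes with replacing the whole aromatic group. No measurement here explains why the methyl on this oxygen lowers the number.

The compounds shown leave open whether a longer chain on this oxygen, such as ethyl or propyl, would lower the number further or raise it again. They also leave open whether an amine or a fluorine in place of the hydroxy would bring the number closer to those of compound 2 and compound 3.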